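Swapping the ring on the hydrazone carbon

A few compounds are considered here, and "the series" means these few. Any claim that something is new, unique, unknown or untested is made for them only; others in the source may bear on it.

Compound 1 `Cc1noc(C)c1/C=N/Nc1ccnc2cc(Cl)ccc12`: 171 uM
Compound 2 `Clc1ccc2c(N/N=C/c3ccc(CN4CCCC4)cc3)ccnc2c1`: 19.5 uM
Compound 3 `Oc1cc(/C=N/Nc2ccnc3cc(Cl)ccc23)ccc1CN1CCCC1`: 152 uM

In a functional assay on KB cells (Homo sapiens) for cytotoxicity (a higher number here means that more compound is needed for the effect, a lower number that less compound is needed), compound 1 gives 171 uM, the highest of the three numbers. Compound 3 gives 152 uM, which lies within the scatter of compound 1, so no order between these two can be read. Compound 2 gives 19.5 uM, a number clearly lower than that of compound 1.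

Compound 4 `Clc1ccc2c(N/N=C/c3ncc[nH]3)ccnc2c1` keeps the shared core of compound 1 and differs from it in one place: 1H-imidazol-2-yl in place of 3,5-dimethyl-1,2-oxazol-4-yl on a carbon with a double bond to nitrogen. Within the data shown here, the only measured step, a 7.8-fold higher number from compound 2 to compound 3 (0.89 log units; beyond the scatter), concerns a different part of the molecule, a hydroxy added to the aromatic ring of compound 2, and so says nothing direct about exchanging one five-membered ring for another on the carbon with a double bond to nitrogen. Among the measured compounds shown here, with no step bearing on this change, the expectation is a number close to that of compound 1, with a step of a 1.1-fold lower number from compound 1 to compound 4 (0.06 log units; within the scatter) expected to stay within the scatter. Compound 4 is therefore estimated at 150 uM, with a range from 50 uM to 400 uM.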

Compound 4, concentration for half-maximal effect: 19.5 uM
Beside the measured number, compound 4's estimate is 7.7-fold (0.89 log units) above it; measured number outside the range, below it.
By their numbers in this assay, from the lowest: compounds 2 and 4 (each within the scatter of the next); then compounds 3 and 1 (each within the scatter of the next).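

In this assay, among these compounds, the exchange of 3,5-dimethyl-1,2-oxazol-4-yl for 1H-imidazol-2-yl gives an 8.8-fold lower number from compound 1 to compound 4 (0.94 log units; beyond the scatter) and is the first step seen at this position. It shows that the group on the carbon with a double bond to nitrogen can move the number beyond the scatter, even when one five-membered aromatic ring with 2 hetero atoms replaces another. The two groups differ in heavy atoms and in their counts of hydrogen-bond donors and acceptors, but no measurement at hand explains the step or singles out one of these differences.

On these data alone, it remains open whether the number would hold if a methyl replaced the hydrogen on the imidazole nitrogen. As far as these compounds go, it is also open how a simple amine or a carboxylic acid would compare with these rings at this position.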